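The source may hold more compounds than are shown below. What is called first, only, known or untested is meant among the compounds shown, and "the series" means these compounds.

Of the compounds shown here, three that share one core have been measured in a functional assay with Alpha-1A adrenergic receptor (Homo sapiens) as the target, read by calcium flux; on this read-out lower numbers stand for smaller maximal responses and higher numbers for larger maximal responses. Compound 1 `Cn1nccc1-c1ccccc1NCC1=NCCN1` gives 108%. Compound 2 `Cn1cc(-c2ccccc2NCC2=NCCN2)cn1` gives 39%. Compound 3 `Cn1cccc1-c1ccccc1NCC1=NCCN1` gives 103%. On these numbers compound 3 stands second highest of the three, with compound 1 within the scatter of it and compound 2 far below it. The steps say the same: a number 5 percentage points lower from compound 1 to compound 3 (within the scatter), while a number 69 percentage points lower from compound 1 to compound 2 (beyond the scatter) and a number 64 percentage points higher from compound 2 to compound 3 (beyond the scatter).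

Compound 4 `Cn1ccnc1-c1ccccc1NCC1=NCCN1` has not been measured. It differs from compound 3 in one place: 1-methyl-1H-imidazol-2-yl in place of 1-methyl-1H-pyrrol-2-yl on an aromatic carbon. For the measured compounds named here, the step that bears most on this is the one from compound 1 to compound 3, which also exchanged one five-membered ring for another at the same carbon and stayed within the scatter, a number 5 percentage points lower from compound 1 to compound 3 (within the scatter). The large drop to compound 2 came with 1-methyl-1H-pyrazol-4-yl, a ring not involved here. For compound 4 the expected step is therefore small, a number 3 percentage points lower from compound 3 to compound 4 (within the scatter), with no change beyond the scatter. The estimate for compound 4 in this assay is 100%, with a likely range from 75% to 120%.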

Compound 4, largest response reached (reported as maximal response), in percent of the reference or control that the assay uses: 88%
For compound 4 the middle estimate is 12 percentage points above the measured one, and the stated range covers the measured number.
By their numbers in this assay, from the lowest: compound 2; then compound 4; then compounds 3 and 1 (each within the scatter of the next).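

In this assay, for the compounds shown here, the earlier compounds suggested that rings attached like the 1-methyl-1H-pyrrol-2-yl group were interchangeable at this aromatic carbon, yet 1-methyl-1H-imidazol-2-yl gives a number 15 percentage points lower from compound 3 to compound 4 (beyond the scatter) and also a number 20 percentage points lower from compound 1 to compound 4 (beyond the scatter) in a modest drop. The loss is still much smaller than the one seen with the 1-methyl-1H-pyrazol-4-yl group, as there is a number 49 percentage points higher from compound 2 to compound 4 (beyond the scatter) in a large rise, so these four rings fall into three separate levels of maximal response rather than two. Nothing on hand explains why the 1-methyl-1H-imidazol-2-yl group lowers the response. The compounds shown leave open how the response changes when this carbon carries something other than a five-membered aromatic ring, such as an amine, a carboxylic acid or a longer chain.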